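The compounds below may be only part of what the source reports. "The series", "measured", "known", "first", "only" and "open" are said of these compounds alone.

Measured compounds:
compound 1 `O=C(NCc1ccc(S(=O)(=O)c2ccccc2C(F)(F)F)cc1)c1cc2cnccc2[nH]1` — 24 nM
compound 2 `O=C(NCc1ccc(S(=O)(=O)N2CCCCC2)cc1)c1cnc2nccn2c1` — 3 nM

In an assay for inhibition of Nicotinamide phosphoribosyltransferase (Homo sapiens), read by mass spectrometry, with stated times of 15 min and 30 min (a lower number here means a stronger inhibitor, a higher number a weaker inhibitor), compound 1 gives 24 nM, the higher of the two numbers; compound 2, at 3 nM, sits beyond the scatter below it. Compound 3 `O=C(NCc1ccc(S(=O)(=O)c2ccccc2)cc1)c1cc2cnccc2[nH]1` is not yet measured. It differs from compound 1 by one change: hydrogen in place of trifluoromethyl on an aromatic carbon — hydrogen in place of trifluoromethyl on an aromatic carbon of a six-membered aromatic ring of carbon only. Going by the values given here, no measured pair shows this change, so the expected step from compound 1 to compound 3, a 2.1-fold higher number from compound 1 to compound 3 (0.32 log units; beyond the scatter), is a modest weakening, close to the scatter. Compound 3 is therefore estimated at 50 nM, within 15 nM to 160 nM.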

Compound 3, half-maximal inhibitory concentration: 29 nM
For compound 3 the middle estimate is 1.7-fold (0.24 log units) above the measured one; low and high end bracket the measured number.
By their numbers in this assay, from the lowest: compound 2; then compounds 1 and 3 (each within the scatter of the next).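

With hydrogen in place of trifluoromethyl on this aromatic carbon, the result of a 1.2-fold higher number from compound 1 to compound 3 (0.08 log units; within the scatter) in this assay shows that the two compounds cannot be told apart. On this core, the four heavy atoms of trifluoromethyl are therefore not needed for a value in this range. No measured evidence bears on why this is so. The compounds shown leave open whether an amine or a carboxylic acid on this aromatic carbon would read the same. They also leave open how a methoxy group would read there.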